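The source may report more compounds than this note shows. Statements on the series, on what has been measured and on what is new or still open speak of the compounds shown alone.

Working notes on a small set of thiosemicarbazide-type analogues tested in a functional assay on MCF7 cells (Homo sapiens) for cytotoxicity, read by MTT assay, with a stated time of 72 h, tested at 3 uM; a lower number here means less inhibition of growth, a higher number more inhibition of growth at the concentration tested.

Three compounds have numbers. Compound 1, `Cc1ccnc(/C(N)=N/NC(=S)N2CCOCC2)c1`, gives 5.07% in this assay. Compound 2, `Cc1cccc(/C(N)=N/NC(=S)N2CCSCC2)n1`, gives 20.6%. Compound 3, `Cc1ccnc(/C(N)=N/NC(=S)N2CCSCC2)c1`, gives 33.8%. Compound 2 and compound 3 are built from the same atoms joined differently; the difference between the two cores is not broken down here, and their two values show compound 3 standing higher than compound 2, a gap beyond the scatter.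

One structural change is measured directly within the set: from compound 3 to compound 1 the change is morpholin-4-yl in place of thiomorpholin-4-yl on a thiocarbonyl carbon, and it produced a step of a number 28.7 percentage points lower from compound 3 to compound 1 (beyond the scatter), a modest fall in growth inhibition.

Compound 4, `Cc1cccc(/C(N)=N/NC(=S)N2CCOCC2)n1`, has not yet been measured. It relates to compound 2 exactly as compound 1 relates to compound 3: the change is morpholin-4-yl in place of thiomorpholin-4-yl on a thiocarbonyl carbon, the same change at the same place. Among the compounds with values here, the only guide to its outcome is the measured step from compound 3 to compound 1. Because compound 2 starts from 20.6%, a lower point than compound 3, the same downward move cannot run as far before the read-out reaches the region of negligible inhibition, so the step from compound 2 to compound 4 is expected to be smaller than the earlier one, about a number 16.6 percentage points lower from compound 2 to compound 4 (beyond the scatter). On that basis compound 4 is estimated to give around 4% in this assay, with a plausible range from 0% to 16%. This rests on a single measured precedent, and the gap between compound 2 and compound 3 shows the core change itself matters, so the estimate is held loosely.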

Compound 4, percent growth inhibition at one concentration: 21.6%
Compound 4: the middle estimate sits 17.6 percentage points below what was measured; measured number outside the range, above it.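

In this assay, morpholin-4-yl in place of thiomorpholin-4-yl on a thiocarbonyl carbon gives a number 1 percentage points higher from compound 2 to compound 4 (within the scatter), so on the core of compound 2 this change leaves growth inhibition at the concentration tested unresolved from that of the parent. The change therefore does not carry over from one core to the other with the same size of effect in this assay: the same change on two cores in this assay, a number 28.7 percentage points lower (beyond the scatter) from compound 3 to compound 1 and a number 1 percentage points higher (within the scatter) from compound 2 to compound 4, 29.7 percentage points apart, beyond the scatter of two such steps

This shows that, for these two pairs, the effect of the change depends on the core it is made on, so a step measured on one core is a poor guide to the step on the other; it does not show why the two cores part ways, which pair is the more typical, or what the change would do on any further core.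

Still open, as far as these compounds go, is whether a piperidine or a dimethylamine on the thiocarbonyl carbon would track the large step seen on one core and the absence of a resolved step on the other. Also open, from the compounds shown here alone, is whether an ethyl group or a longer chain in place of the methyl group on either core would alter the difference between the two steps.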